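A few compounds are considered here, and "the series" means these few. Any claim that something is new, unique, unknown or untested is made for them only; others in the source may bear on it.

Of the compounds shown here, three sharing one core have been measured in an assay on cells for antagonist activity at transient receptor potential cation channel subfamily V member 1 (Homo sapiens), read by FLIPR and calcium flux, with a stated time of 6 min; a lower number here means a stronger inhibitor, a higher number a weaker inhibitor. Compound 1 `CCOc1nc(C(C)(C)C)ccc1CNC(=O)C(C)c1ccc(NS(C)(=O)=O)c(F)c1` gives 14.8 nM in this assay. Compound 2 `CCCOc1nc(C(C)(C)C)ccc1CNC(=O)C(C)c1ccc(NS(C)(=O)=O)c(F)c1` gives 1.7 nM, and compound 3 `CC(C(=O)NCc1ccc(C(C)(C)C)nc1OC1CCCCC1)c1ccc(NS(C)(=O)=O)c(F)c1` gives 2.5 nM. Compound 3 thus stands second highest of the three numbers: a 1.5-fold higher number from compound 2 to compound 3 (0.17 log units; within the scatter), so compound 2 and compound 3 cannot be told apart, whereas a 5.9-fold lower number from compound 1 to compound 3 (0.77 log units; beyond the scatter).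

Compound 4 `COc1ccc(CSc2nc(C(C)(C)C)ccc2CNC(=O)C(C)c2ccc(NS(C)(=O)=O)c(F)c2)cc1` has not yet been measured. It differs from compound 3 in one place, ((4-methoxybenzyl)sulfanyl in place of cyclohexyloxy on an aromatic carbon). Among the compounds with values here, no measured step exchanges the oxygen on the aromatic ring for a sulfur, and none brings in a second aromatic ring, so the measured steps bear on this change only loosely. What they do show is that larger groups on that oxygen have not raised the number: an 8.7-fold lower number from compound 1 to compound 2 (0.94 log units; beyond the scatter) and a 5.9-fold lower number from compound 1 to compound 3 (0.77 log units; beyond the scatter), while a 1.5-fold higher number from compound 2 to compound 3 (0.17 log units; within the scatter). Within the data shown here, on that basis a step no larger than the scatter is expected in this assay, in either direction, and the range is kept wide: the sulfur and the added aromatic ring have no precedent among the measured compounds. Compound 4 is estimated at 4 nM, within 1.5 nM to 15 nM, which corresponds to an expected 1.6-fold higher number from compound 3 to compound 4 (0.20 log units; within the scatter).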

Compound 4, inhibition constant: 3.5 nM
Compound 4: the middle estimate sits 1.1-fold (0.06 log units) above what was measured; the measured number falls inside the stated range.
By their numbers in this assay, from the lowest: compounds 2, 3 and 4 (each within the scatter of the next, the first and the last beyond it); then compound 1.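

In this assay, a 1.4-fold higher number from compound 3 to compound 4 (0.15 log units; within the scatter) shows that this position, on an aromatic carbon next to the ring nitrogen, tolerates a sulfur in place of the oxygen and a six-membered aromatic ring in place of a non-aromatic one, with more heavy atoms overall and no step beyond the scatter. The comparison with the two straight chains is less even: a 2.1-fold higher number from compound 2 to compound 4 (0.31 log units; beyond the scatter) is a modest step just past the scatter, while a 4.2-fold lower number from compound 1 to compound 4 (0.63 log units; beyond the scatter) keeps the new group clearly on the low side of ethoxy, so the large (4-methoxybenzyl)sulfanyl group is not level with propoxy, though it is level with cyclohexyloxy. No measurement shown here accounts for these numbers.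

The sulfur and the aromatic ring enter together in a single step, and the compounds shown cannot separate them: a propylsulfanyl group would test the sulfur alone, and a (4-methoxybenzyl)oxy group would test the aromatic ring alone. Also open, from the compounds shown here alone, are the part played by the methoxy on that ring, which a plain benzylsulfanyl group would address, and how an amine on this same carbon would read.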